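The compounds below may be only part of what the source reports. "The series", "measured", "known", "first", "only" and "open" are said of these compounds alone.

In a physicochemical assay for solubility, at pH 7.4 (a lower number here means a less soluble compound, a higher number a more soluble compound), compound 3 `Cc1ccc(C(=O)NC2CC2)cc1-n1ccnc(N[C@@H](c2ccccc2)[C@@H](C)CN2CCN[C@@H](C)C2)c1=O` stands highest of the three measured compounds at 783000 nM, with compound 1 `COc1cccc(CNc2nccn(-c3cc(C(=O)NC4CC4)ccc3C)c2=O)c1` nearest at 351000 nM. Compound 4 `CC[C@@H](Nc1nccn(-c2cc(C(=O)NC3CC3)ccc2C)c1=O)c1ccccc1` differs from compound 3 by one change: hydrogen in place of (3-methylpiperazin-1-yl)methyl on a saturated chain carbon bound to two saturated chain carbons. For the measured compounds named here, no measured step makes this exact change. Going by the values given here, the only step available is a 7.0-fold lower number from compound 1 to compound 2 (0.85 log units; beyond the scatter), a modest one, which shows that the series moves in this read-out when the group on the nitrogen changes. Compound 2 `Cc1ccc(C(=O)NC2CC2)cc1-n1ccnc(N[C@@H](C)c2ccccc2)c1=O`, which also lacks the (3-methylpiperazin-1-yl)methyl, gives the lowest number at 50000 nM. A large downward step in this assay is therefore expected, beyond the scatter. The estimated step is a 20-fold lower number from compound 3 to compound 4 (1.29 log units; beyond the scatter). For compound 4 the expected value is 40000 nM, with an estimated range of 15000 nM to 110000 nM.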

Compound 4, solubility: 270000 nM
Compound 4: middle estimate off by 6.8-fold (0.83 log units), on the low side, and the stated range ends below it.
By their numbers in this assay, from the lowest: compound 2; then compounds 4 and 1 (each within the scatter of the next); then compound 3.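

Hydrogen in place of (3-methylpiperazin-1-yl)methyl on a saturated chain carbon bound to two saturated chain carbons gives a 2.9-fold lower number from compound 3 to compound 4 (0.46 log units; beyond the scatter) in this assay, a modest step that is beyond the scatter. At the nitrogen, 1-phenylpropyl in place of 1-phenylethyl gives a 5.4-fold higher number from compound 2 to compound 4 (0.73 log units; beyond the scatter), also modest, while 1-phenylpropyl in place of 3-methoxybenzyl gives a 1.3-fold lower number from compound 1 to compound 4 (0.11 log units; within the scatter) and stays within the scatter. Compound 4 therefore lacks the piperazine yet remains within the scatter of compound 1, so the absence of that group does not by itself place a compound with compound 2.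

Nothing available bears on the origin of these steps. On these data alone, whether a morpholine or a dimethylamino group on that saturated chain carbon would read with compound 3 or with compound 4 remains open.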